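The source may hold more compounds than are shown below. What is called first, only, known or untested is meant among the compounds shown, and "the series" means these compounds.

Within the data shown here, compound 1 `Cc1cc(-c2ccccc2)n(/C(N)=N/S(=O)(=O)c2cc(C)c(Cl)cc2SCc2ccccc2C(F)(F)F)n1` is the weakest of the three measured members in a functional assay on MCF7 cells (Homo sapiens) for cytotoxicity, read by MTT assay, with a stated time of 72 h (a lower number here means a stronger inhibitor, a higher number a weaker inhibitor), where compound 1 gives 101000 nM. Its nearest neighbour is compound 2 `Cc1cccc(CSc2cc(Cl)c(C)cc2S(=O)(=O)/N=C(\N)n2nccc2-c2ccccc2)c1`, which in this assay gives 47000 nM, and the furthest is compound 3 `Cc1cc(S(=O)(=O)/N=C(\N)n2nccc2-c2ccccc2)c(SCc2ccccc2C)cc1Cl`, which in this assay gives 23000 nM; both gaps from compound 1 lie beyond the scatter. Among the measured compounds shown here, the only single-change step measured is a 2.0-fold lower number from compound 2 to compound 3 (0.31 log units; beyond the scatter), showing that exchanging one methylphenyl for another on the saturated chain carbon bound to a sulfur shifts the number only modestly.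

Compound 4 `Cc1cc(-c2ccccc2)n(/C(N)=N/S(=O)(=O)c2cc(C)c(Cl)cc2SCc2cccc(Cl)c2)n1` has not yet been measured. It differs from compound 1 by 3-chlorophenyl in place of 2-(trifluoromethyl)phenyl on a saturated chain carbon bound to a sulfur. For the measured compounds named here, the step from compound 2 to compound 3 bears on this change only through its place: the group that changes is the same, but neither 2-(trifluoromethyl)phenyl nor 3-chlorophenyl is among the methylphenyl groups measured, and no measured pair weighs a chlorine against a trifluoromethyl here. He therefore expects compound 4 to land near compound 1, with a modest step in either direction being plausible, and estimates compound 4 at 60000 nM, within 20000 nM to 180000 nM, an expected shift of a 1.7-fold lower number from compound 1 to compound 4 (0.23 log units; within the scatter).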

Compound 4, half-maximal inhibitory concentration: 25000 nM
For compound 4 the middle estimate is 2.4-fold (0.38 log units) above the measured one, within the range that was stated.
By their numbers in this assay, from the lowest: compounds 3, 4 and 2 (each within the scatter of the next, the first and the last beyond it); then compound 1.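

In this assay, 3-chlorophenyl in place of 2-(trifluoromethyl)phenyl on a saturated chain carbon bound to a sulfur gives a 4.0-fold lower number from compound 1 to compound 4 (0.61 log units; beyond the scatter), so this place also responds on the core of compound 1, whereas the earlier single-change step, a 2.0-fold lower number from compound 2 to compound 3 (0.31 log units; beyond the scatter), was read on a different core and only between methylphenyl groups. Among these compounds, with the core held fixed, the exchange of these two substituted phenyl groups alone is enough to produce a step beyond the scatter, which the earlier compounds could not show, as compound 1 differs from each of them in more than one place. No measurement given here explains the step.

From the compounds shown here alone, the step exchanges trifluoromethyl for chlorine and 2-substitution for 3-substitution together, so it remains open whether 2-chlorophenyl or 3-(trifluoromethyl)phenyl at this place would give a number nearer that of compound 1 or that of compound 4. Going by these compounds, it is also open how this core would respond to an unsubstituted phenyl, or to a phenyl group carrying an amine or a carboxylic acid, on the same chain carbon.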